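The source may report more compounds than this note shows. Statements on the series, on what has been measured and on what is new or still open speak of the compounds shown alone.

Measured so far in a functional assay on A549 cells (Homo sapiens) for antiproliferative activity, read by MTT assay, with a stated time of 48 h; a lower number here means a stronger inhibitor, a higher number a weaker inhibitor:

- compound 1, `Cc1ccc(/C=C/C(=O)Nc2nnc(-c3ccc(C)cc3)s2)cc1`: 1.08 ug/mL
- compound 2, `Cc1ccc(-c2nnc(NC(=O)/C=C/c3ccccc3)s2)cc1`: 1.38 ug/mL
- compound 3, `O=C(/C=C/c1ccccc1)Nc1nnc(-c2ccc(Br)cc2)s1`: 2.18 ug/mL

Compound 1 and compound 2 differ by methyl in place of hydrogen on an aromatic carbon, and the step is a 1.3-fold lower number from compound 2 to compound 1 (0.11 log units; within the scatter). Compound 3 differs from compound 2 by bromo in place of methyl on an aromatic carbon, with the step of a 1.6-fold higher number from compound 2 to compound 3 (0.20 log units; within the scatter). Among the compounds with values here, compound 3 and compound 1 have no counted step between them; their two values simply stand as given, with compound 3 holding the higher number of the three.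

Compound 4, `Cc1ccc(/C=C/C(=O)Nc2nnc(-c3ccc(Br)cc3)s2)cc1`, is not yet measured. It differs from compound 3 by methyl in place of hydrogen on an aromatic carbon. This is the same change as that from compound 2 to compound 1; the cores of compound 3 and compound 2 differ by bromo in place of methyl on an aromatic carbon, as described above.

Within the data shown here, for compound 4 in this assay the expected step is a 1.3-fold lower number from compound 3 to compound 4 (0.11 log units; within the scatter), resting on the one earlier instance of this change, which from compound 2 to compound 1 gave a 1.3-fold lower number from compound 2 to compound 1 (0.11 log units; within the scatter). The expectation for compound 4 is therefore 1.7 ug/mL, with a range estimated from 1 ug/mL to 3 ug/mL.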

Compound 4, half-maximal inhibitory concentration: 1.51 ug/mL
Estimate against measurement, compound 4: 1.1-fold (0.05 log units) above; the range from low to high includes it.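

In this assay, the change from phenyl to 4-methylphenyl gives a 1.4-fold lower number from compound 3 to compound 4 (0.16 log units; within the scatter), and it reads the same on both cores: the same change on two cores in this assay, a 1.3-fold lower number (0.11 log units; within the scatter) from compound 2 to compound 1 and a 1.4-fold lower number (0.16 log units; within the scatter) from compound 3 to compound 4, 1.1-fold (0.05 log units) apart, within the scatter of two such steps

The swap of methyl for bromo gives a 1.4-fold higher number from compound 1 to compound 4 (0.15 log units; within the scatter), and it also reads the same on both cores: the same change on two cores in this assay, a 1.6-fold higher number (0.20 log units; within the scatter) from compound 2 to compound 3 and a 1.4-fold higher number (0.15 log units; within the scatter) from compound 1 to compound 4, 1.1-fold (0.05 log units) apart, within the scatter of two such steps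

Within the data shown here, both changes therefore carry from one core to the other in these four compounds without a detectable difference, but every step lies within the scatter, so this agreement shows only that neither change has a resolved effect here, not that a real effect transfers or that the two rings act independently.

The compounds shown leave open whether a step large enough to stand beyond the scatter would carry between cores in the same way. Also open, on these data alone, is how a methoxy group, a chloro group, an amine or a carboxylic acid would read in place of the methyl or bromo.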